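A few compounds are considered here, and "the series" means these few. Any claim that something is new, unique, unknown or untested is made for them only; others in the source may bear on it.

In a functional assay on MCF7 cells (Homo sapiens) for inhibition, read by MTT assay (a higher number here means a weaker inhibitor of growth, a lower number a stronger inhibitor of growth), compound 3 `COc1ccc(C(=O)Nc2cccc(-c3cc(=O)c4c(OC)c(OC)c(OC)cc4o3)c2)cc1` gives 6870 nM and sits level with compound 2 `COc1cc2oc(-c3cccc(NC(=O)c4ccc(Cl)cc4)c3)cc(=O)c2c(OC)c1OC` at 8780 nM within the scatter, while compound 1 `COc1cc2oc(-c3cccc(NC(=O)c4ccccc4Br)c3)cc(=O)c2c(OC)c1OC` stands well higher at 55000 nM on this scale. Compound 4 `COc1cccc(C(=O)Nc2cccc(-c3cc(=O)c4c(OC)c(OC)c(OC)cc4o3)c2)c1` differs from compound 3 by one change, 3-methoxyphenyl in place of 4-methoxyphenyl on a carbonyl carbon with 3-methoxyphenyl in place of 4-methoxyphenyl on a carbonyl carbon. Changes at that carbonyl carbon gave the modest 8.0-fold lower number from compound 1 to compound 3 (0.90 log units; beyond the scatter) and a 6.3-fold lower number from compound 1 to compound 2 (0.80 log units; beyond the scatter) as steps, but both start from compound 1. Among the measured compounds shown here, no measured step shifts the methoxy group itself. Going by the small 1.3-fold lower number from compound 2 to compound 3 (0.11 log units; within the scatter) as the closer guide, no step beyond the scatter is expected in this assay for this change. The expected step is a 1.1-fold higher number from compound 3 to compound 4 (0.04 log units; within the scatter) by this estimate. Compound 4 is estimated at 7500 nM with an expected range from 3000 nM to 18000 nM in this read-out.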

Compound 4, concentration for 50% growth inhibition: 7670 nM
Compound 4: the middle estimate sits 1.0-fold (0.01 log units) below what was measured, and the stated range covers the measured number.
By their numbers in this assay, from the lowest: compounds 3, 4 and 2 (each within the scatter of the next); then compound 1.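

In this assay, the first measured shift of the methoxy group itself, from 4-methoxyphenyl to 3-methoxyphenyl on the carbonyl carbon, gives a 1.1-fold higher number from compound 3 to compound 4 (0.05 log units; within the scatter) and so separates neither compound. The 4-chlorophenyl swap gives a 1.1-fold lower number from compound 2 to compound 4 (0.06 log units; within the scatter) as well, whereas the 2-bromophenyl swap alone stands apart, with a 7.2-fold lower number from compound 1 to compound 4 (0.86 log units; beyond the scatter) in this series. Nothing measured here beyond these numbers bears on what lies behind them.

From the compounds shown here alone, it remains open whether 2-methoxyphenyl would read like compound 1 or like the other compounds, which would separate the place of the group from the bromine. Going by these compounds, how an aminophenyl or a carboxyphenyl group on that carbonyl carbon would read also remains open.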